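Piperazine in Place of the Hydroxyethylamine Chain

The compounds below may be only part of what the source reports. "The series", "measured", "known", "first", "only" and "open" are said of these compounds alone.

Compound 1, `CC(C)c1n[nH]c2c(NCc3ccc(-c4ccccn4)cc3)nc(NCCO)nc12`, is one of two measured compounds in this set. In a functional assay on G-361 cells (Homo sapiens) for cytotoxicity, read by fluorescence, with a stated time of 72 h (on this read-out higher numbers stand for weaker inhibition and lower numbers for stronger inhibition), compound 1 gives 39 nM. Its companion, compound 2, `CC(C)c1n[nH]c2c(NCc3ccc(-c4ccccn4)cc3)nc(NCC(C)(C)O)nc12`, carries a 1-hydroxy-1-methylethyl group in place of the hydroxymethyl on the saturated chain carbon bound to the ring nitrogen; in this assay compound 2 gives 48 nM. Going by the values given here, the only measured step, a 1.2-fold higher number from compound 1 to compound 2 (0.09 log units; within the scatter), leaves the two indistinguishable, so compound 1 stands alongside compound 2 with no separation beyond the scatter.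

Compound 3, `CC(C)c1n[nH]c2c(NCc3ccc(-c4ccccn4)cc3)nc(N3CCNCC3)nc12`, departs from compound 1 by piperazin-1-yl in place of (2-hydroxyethyl)amino on an aromatic carbon. Among the compounds with values here, the one measured step concerns only the far end of the hydroxyalkyl chain and does not alter the (2-hydroxyethyl)amino attachment itself, so it bears only loosely on this exchange of the whole group for piperazin-1-yl. With nothing in the data pointing one way or the other, the expected step in this assay from compound 1 to compound 3 is a 1.5-fold higher number from compound 1 to compound 3 (0.19 log units; within the scatter), a change not clearly beyond the scatter. Compound 3 is therefore estimated at 60 nM, within a range from 20 nM to 200 nM.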

Compound 3, half-maximal inhibitory concentration: 64 nM
Estimate against measurement, compound 3: 1.1-fold (0.03 log units) below, and the stated range covers the measured number.
By their numbers in this assay, from the lowest: compounds 1, 2 and 3 (each within the scatter of the next).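

In this assay piperazin-1-yl in place of (2-hydroxyethyl)amino gives a 1.6-fold higher number from compound 1 to compound 3 (0.22 log units; within the scatter) and piperazin-1-yl in place of (2-hydroxy-2-methylpropyl)amino gives a 1.3-fold higher number from compound 2 to compound 3 (0.12 log units; within the scatter) on the same aromatic carbon, so both exchanges stay within the scatter. The earlier pair had varied only the far end of an open hydroxyalkyl chain, whereas this result replaces the whole group on the aromatic carbon between two ring nitrogen atoms: an open chain carrying oxygen gives way to a six-membered non-aromatic ring with no oxygen, and the three compounds still cannot be told apart on this read-out. Nothing available on these compounds accounts for this result.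

The compounds shown leave open whether the ring nitrogen of piperazin-1-yl matters at this position, a question that morpholin-4-yl, with oxygen at that ring position, or 4-methylpiperazin-1-yl could address. They also leave open how a longer chain such as (3-hydroxypropyl)amino, or a carboxylic acid at the end of the chain, would read in this assay on the same core.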